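A few compounds are considered here, and "the series" means these few. Any claim that something is new, unique, unknown or untested is made for them only; others in the source may bear on it.

Compound 1 `CN(C(=O)NC(=O)c1cccc(C(F)(F)F)c1)c1nc(C(F)(F)F)c(C(=O)N/N=C/c2cccc(C(F)(F)F)c2)s1` gives 5.79 ug/mL in a functional assay on HepG2 cells (Homo sapiens) for inhibition, read by MTT assay, with a stated time of 72 h; on this read-out higher numbers stand for weaker inhibition and lower numbers for stronger inhibition. Of the two numbers shown, compound 1 holds the lowest, though the step of a 1.8-fold higher number from compound 1 to compound 2 (0.25 log units; within the scatter) is within the scatter, so compound 2 `CN(C(=O)NC(=O)c1cccc(C(F)(F)F)c1)c1nc(C(F)(F)F)c(C(=O)N/N=C/c2ccccc2C(F)(F)F)s1`, at 10.4 ug/mL, cannot be separated from it. Compound 3 `CN(C(=O)NC(=O)c1ccc(C(F)(F)F)cc1)c1nc(C(F)(F)F)c(C(=O)N/N=C/c2ccc(C(F)(F)F)cc2)s1` yields only a limit, > 100 ug/mL, in this assay (the limit of > 100 ug/mL in this assay, at which 1 of the 3 values shown sits). Compound 4 `CN(C(=O)NC(=O)c1ccc(F)c(F)c1)c1nc(C(F)(F)F)c(C(=O)N/N=C/c2cccc(C(F)(F)F)c2)s1` differs from compound 1 by 3,4-difluorophenyl in place of 3-(trifluoromethyl)phenyl on a carbonyl carbon. Within the data shown here, no measured step touches this carbonyl position; the only measured step sits on the carbon with a double bond to nitrogen and was small. The step is therefore expected to stay close to the scatter, a 1.6-fold higher number from compound 1 to compound 4 (0.19 log units; within the scatter). Compound 4 is estimated at 9 ug/mL, between 3 ug/mL and 40 ug/mL.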

Compound 4, half-maximal inhibitory concentration: 5.6 ug/mL
Compound 4: the middle estimate sits 1.6-fold (0.21 log units) above what was measured; low and high end bracket the measured number.
By their numbers in this assay, from the lowest: compounds 4, 1 and 2 (each within the scatter of the next). At a limit, above all of these: compound 3.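

Among these compounds, on this carbonyl carbon, which no earlier step had touched, 3,4-difluorophenyl and 3-(trifluoromethyl)phenyl cannot be told apart in this assay: the step is a 1.0-fold lower number from compound 1 to compound 4 (0.01 log units; within the scatter). This position thus joins the carbon with a double bond to nitrogen in giving only a step within the scatter. Nothing shown gives a reason for this result.

On these data alone, what a carbonyl carbon bearing an amine or a carboxylic acid on this phenyl ring would give remains open. So does the effect of a longer chain in place of the ring.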